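Lengthening a thioether chain: expected effect on macrophage cytotoxicity

The source may report more compounds than this note shows. Statements on the series, on what has been measured and on what is new or still open speak of the compounds shown alone.

Compound 1 `CCCSc1nnc(COc2ccccc2C2=NOC(c3ccc(Cl)cc3Cl)C2)n1NC(=O)c1ccccc1`: 14.8 ug/mL
Compound 2 `CC(C)CSc1nnc(COc2ccccc2C2=NOC(c3ccc(Cl)cc3Cl)C2)n1NC(=O)CCl`: "not determined" (no result reported)
Compound 3 `CCCSc1nnc(COc2ccccc2C2=NOC(c3ccc(Cl)cc3Cl)C2)n1NC(C)=O`: 128 ug/mL

In an ADME assay (MDM cells, Homo sapiens) for cytotoxicity, read by resazurin assay, with a stated time of 3 days (on this read-out lower numbers stand for stronger inhibition and higher numbers for weaker inhibition), compound 1 gives 14.8 ug/mL, the lowest of the two numbers reported, while compound 3 gives 128 ug/mL. For the measured compounds named here, the single measured step, an 8.6-fold higher number from compound 1 to compound 3 (0.94 log units; beyond the scatter), replaces phenyl with methyl on a carbonyl carbon. Compound 2 carries an isobutyl thioether and a chloroacetyl amide, but in this assay compound 2 gives "not determined" (no result reported).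

Compound 4 `CCCCSc1nnc(COc2ccccc2C2=NOC(c3ccc(Cl)cc3Cl)C2)n1NC(=O)c1ccccc1` differs from compound 1 only by methyl in place of hydrogen on a saturated chain carbon, three bonds along the chain from a sulfur; read one bond further out, this is propyl to butyl on the saturated chain attached to sulfur. Going by the values given here, none of the measured steps touches this chain, so nothing here indicates how the number in this assay responds to such a change. Among the compounds with values here, the sole measured step concerns the amide end of the molecule and does not bear on the thioether chain. Within the data shown here, with no guiding step, the expectation for compound 4 is a number close to that of compound 1, a step of a 1.0-fold higher number from compound 1 to compound 4 (0.01 log units; within the scatter) that stays within the scatter. The estimate for compound 4 is therefore 15 ug/mL, with a range from 6 ug/mL to 40 ug/mL.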

Compound 4, half-maximal inhibitory concentration: 2.5 ug/mL
The estimate for compound 4 lay 6.0-fold (0.78 log units) above the measured number; measured number below the stated range.
By their numbers in this assay, from the lowest: compound 4; then compound 1; then compound 3.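

In this assay, the saturated chain attached to sulfur proves to be a sensitive position: propyl to butyl gives a 5.9-fold lower number from compound 1 to compound 4 (0.77 log units; beyond the scatter). The earlier step, an 8.6-fold higher number from compound 1 to compound 3 (0.94 log units; beyond the scatter), showed a response only at the amide end of the molecule, whereas this result shows that adding one methyl at the far end of the thioether chain also shifts the number beyond the scatter, towards stronger inhibition. Nothing available explains why this small change has such an effect.

As far as these compounds go, it remains open whether a longer chain such as pentyl would lower the number further, or whether the number would rise again. It is also unknown whether butyl would produce a similar shift with methyl rather than phenyl on the carbonyl carbon.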